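Removing the Formyl Group from Compound 2

The source may hold more compounds than are shown below. What is called first, only, known or untested is meant among the compounds shown, and "the series" means these compounds.

In a functional assay on NPC-TW01 cells (Homo sapiens) for inhibition, read by MTT assay, with a stated time of 72 h (a lower number here means a stronger inhibitor of growth, a higher number a weaker inhibitor of growth), compound 1 (`Nc1cc(-c2ccc(Cl)cc2)nn1-c1ccc(Br)cc1`) gives 64400 nM as its reading. Compound 2 (`CN(C)/C=N/c1c(C=O)c(-c2ccccc2)nn1-c1ccccc1`) gives 9300 nM in the same test, the lower of the two numbers, and the gap between them lies beyond the scatter. Compound 3 (`CN(C)/C=N/c1c(C=O)c(-c2ccc(Cl)cc2)nn1-c1ccc(Br)cc1`) reports only a limit (> 100000 nM) and no number.

The next compound to be tested is compound 4 (`CN(C)/C=N/c1cc(-c2ccccc2)nn1-c1ccccc1`), which carries hydrogen in place of formyl on an aromatic carbon of compound 2 (hydrogen in place of formyl on an aromatic carbon). Among the measured compounds shown here, no measured pair of compounds differs in a single place, so this change has no direct precedent in the data. The two formyl-bearing compounds do not agree: compound 2 has the lower number, while compound 3 stands at its limit. Compound 1, which has no formyl, gives 64400 nM and so suggests a higher number without the group, although it differs from compound 4 in other places too. A small rise in this assay is therefore expected, with compound 4 a somewhat weaker inhibitor of growth. The expected change is a 2.2-fold higher number from compound 2 to compound 4 (0.33 log units; beyond the scatter) and lies close to the edge of the scatter. Compound 4 is estimated at 20000 nM with an expected range from 6000 nM to 70000 nM in this test.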

Compound 4, concentration for 50% growth inhibition: > 100000 nM
Compound 4 was reported as a limit; the forecaster's own chance of this, stated with the estimate: 15%; middle value at least 5.0-fold (0.69 log units) away from the limit.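

Among the compounds shown here, replacing formyl with hydrogen on this aromatic carbon gives the only comparison here in which two compounds differ in a single place, and in this assay it produces an at least 10-fold higher number from compound 2 to compound 4 (1.03 log units; beyond the scatter). This shows that the position is far from indifferent in this series: with both phenyl groups unchanged, the formyl-bearing compound 2 gives a measurable reading, whereas the hydrogen-bearing compound 4 does not. The step can be given only as a lower bound, because the reading for compound 4 is a limit rather than a number: the limit of > 100000 nM in this assay, at which 2 of the 4 values shown sit.

The compounds shown leave open whether formyl itself matters or whether another group on this carbon, such as a nitrile, a hydroxymethyl, a carboxylic acid or an amide, would keep a reading of this kind. They also leave open how far the true value of compound 4 lies from that of compound 2, and whether removing formyl has a comparable effect when the two phenyl groups carry other substituents.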